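The source may report more compounds than this note shows. Statements on the series, on what has been measured and on what is new or still open speak of the compounds shown alone.

Measured so far in an assay for inhibition of Indoleamine 2,3-dioxygenase 1 (Homo sapiens), read by spectrophotometry, with stated times of 1 h and 4 h; a higher number here means a weaker inhibitor, a lower number a stronger inhibitor:
Compound 1, `CC(=O)Nc1ccc(S(=O)(=O)NNc2ccc(Br)cc2)cc1`, gives 130 nM.
Compound 2, `CC(=O)Nc1ccc(S(=O)(=O)NNc2cccc(Br)c2)cc1`, gives 255 nM.
Compound 3, `O=S(=O)(NNc1ccc(Br)cc1)c1ccccc1`, gives 172 nM.

Compound 3 holds the second highest of these three numbers, yet its gap to compound 1 and its gap to compound 2 both lie within the scatter, so the three cannot be ranked. Compound 4, `O=S(=O)(NNc1ccc(Br)cc1)c1ccc(Br)cc1`, differs from compound 3 in one place: bromo in place of hydrogen on an aromatic carbon. For the measured compounds named here, no measured step makes this exact change. The closest guide is the step from compound 1 to compound 3, a 1.3-fold higher number from compound 1 to compound 3 (0.12 log units; within the scatter), which also exchanges a group for hydrogen on an aromatic carbon and stays within the scatter, as does a 2.0-fold higher number from compound 1 to compound 2 (0.29 log units; within the scatter). A step within the scatter is therefore expected in this assay, a 1.1-fold lower number from compound 3 to compound 4 (0.03 log units; within the scatter). Compound 4 is expected to give about 160 nM, from 70 nM to 360 nM.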

Compound 4, half-maximal inhibitory concentration: 85 nM
For compound 4 the middle estimate is 1.9-fold (0.27 log units) above the measured one, within the range that was stated.
By their numbers in this assay, from the lowest: compounds 4, 1, 3 and 2 (each within the scatter of the next, the first and the last beyond it).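

In this assay, for the compounds shown here, bromo on this aromatic carbon, para to a large group, gives the only step so far that lies beyond the scatter: a 2.0-fold lower number from compound 3 to compound 4 (0.31 log units; beyond the scatter). Replacing acetamido at the same place gives no such separation, a 1.5-fold lower number from compound 1 to compound 4 (0.18 log units; within the scatter), so bromo stands apart from hydrogen here but not from acetamido. Nothing available explains the step from hydrogen to bromo. As far as these compounds go, whether chloro, methyl or methoxy at this carbon would give a similar step remains open, as does whether the step would hold with 3-bromophenyl on the amine nitrogen.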